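Ring Size at the Ether Oxygen and Cell Toxicity

The compounds below may be only part of what the source reports. "The series", "measured", "known", "first", "only" and "open" are said of these compounds alone.

Compound 1, `Cc1cc(OC2CCCC2)nc(Nc2ccc(C#N)cc2)n1`: 1050 nM
Compound 2, `N#Cc1ccc(Nc2nccc(OC3CCCC3)n2)cc1`: >= 339000 nM

Among the compounds with values here, in an ADME assay on MT4 cells (Homo sapiens) for cytotoxicity, read by MTT assay (on this read-out higher numbers stand for lower toxicity in this test and lower numbers for higher toxicity in this test), compound 1 gives 1050 nM, the only number among the values shown. Compound 2 gives only a limit of the assay, >= 339000 nM. Within the data shown here, the one measured step, an at least 320-fold higher number from compound 1 to compound 2 (2.50 log units; beyond the scatter), ends at the limit of >= 339000 nM in this assay, at which 1 of the 2 values shown sits.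

Compound 3, `Cc1cc(OC2CCCCC2)nc(Nc2ccc(C#N)cc2)n1`, differs from compound 1 by cyclohexyl in place of cyclopentyl on an oxygen on an aromatic ring. Among the measured compounds shown here, no measured step touches the ring on the oxygen; the single measured step concerns the methyl. A step within the scatter in this assay is therefore expected. Compound 3 is estimated to give 1500 nM, between 400 nM and 8000 nM. The expected step is a 1.4-fold higher number from compound 1 to compound 3 (0.15 log units; within the scatter).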

Compound 3, half-maximal cytotoxic concentration: 320 nM
Compound 3: the middle estimate sits 4.7-fold (0.67 log units) above what was measured; measured number outside the range, below it.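

The ring on the ether oxygen is not a silent place in this assay: cyclohexyl in place of cyclopentyl gives a 3.3-fold lower number from compound 1 to compound 3 (0.52 log units; beyond the scatter), so one added ring carbon here moves the read-out towards higher toxicity in this test. Within the data shown here, the methyl is therefore not the only part of compound 1 on which this number depends. Nothing shown here accounts for the shift.

From the compounds shown here alone, whether a cyclobutyl ring, an open butyl chain or a phenyl ring on the oxygen would lower or raise the number stays open. So does whether the cyclohexyl change acts in the same way when hydrogen replaces the methyl.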